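Methoxy for methyl on the core of compound 1

The source may report more compounds than this note shows. Statements on the series, on what has been measured and on what is new or still open speak of the compounds shown alone.

Compound 1 `Cc1ccc2occ(C(=O)Nc3ccccc3)c(=O)c2c1`: 21.4 nM
Compound 2 `Cc1ccc2occ(C(=O)Nc3cccc(Cl)c3)c(=O)c2c1`: 4.2 nM

Going by the values given here, in an assay on cells for inhibition of Amine oxidase [flavin-containing] B (Homo sapiens), read by fluorescence and Amplex Red, using microsomes, with a stated time of 15 min (a higher number here means a weaker inhibitor, a lower number a stronger inhibitor), compound 1 gives 21.4 nM, the highest of the two numbers so far; the nearest is compound 2, with the step of a 5.1-fold lower number from compound 1 to compound 2 (0.71 log units; beyond the scatter). Compound 3 `COc1ccc2occ(C(=O)Nc3ccccc3)c(=O)c2c1` differs from compound 1 by methoxy in place of methyl on an aromatic carbon, on an aromatic carbon of the core that is meta to a fused ring and para to a fused ring. Among the compounds with values here, no measured step touches this position; the one step known, from compound 1 to compound 2, concerns the amide-bound ring instead. The expectation for compound 3 is therefore a step of about a 1.2-fold higher number from compound 1 to compound 3 (0.07 log units; within the scatter), within the scatter, and compound 3 is estimated at 25 nM, between 8 nM and 80 nM.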

Compound 3, half-maximal inhibitory concentration: 41.8 nM
The estimate for compound 3 lay 1.7-fold (0.22 log units) below the measured number; the measured number falls inside the stated range.
By their numbers in this assay, from the lowest: compound 2; then compounds 1 and 3 (each within the scatter of the next).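

This position of the core, meta to a fused ring and para to a fused ring, now has a measured step: in this assay, methoxy in place of methyl gives a 2.0-fold higher number from compound 1 to compound 3 (0.29 log units; within the scatter) and so does not separate the two groups. No available evidence bears on this result.

Still open, going by these compounds, is whether an amine, a hydroxy group or a longer chain such as ethoxy at this position would give a step beyond the scatter. Also open, on these data alone, is whether chloro on the amide-bound ring, which gives a 5.1-fold lower number from compound 1 to compound 2 (0.71 log units; beyond the scatter) on the methyl core, gives a similar step on the methoxy core.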